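This account rests on a few compounds, and the source may have more. Where it says the series, first, only, none or still open, it means among the compounds named here.

Working notes on the series. In an assay on isolated protein for binding affinity to Leucine-rich repeat serine/threonine-protein kinase 2 variant G2019S (Homo sapiens), read by TR-FRET and LanthaScreen, with a stated time of 2 h (a lower number here means a stronger inhibitor, a higher number a weaker inhibitor), compound 1 `Cc1c(Nc2nc(N)c3c(C#N)c(N4CCC[C@H]4C)n(C)c3n2)cnn1C` gives 3 nM and is the lowest number of the three. Compound 2 `Cc1cn(C)nc1Nc1cc2c(c(N)n1)c(C#N)c(N1CCC[C@H]1C)n2C` gives 75 nM in this assay, the second highest of the three numbers: its nearest neighbour is compound 3 `CN(C)c1c(C#N)c2c(N)ncnc2n1C`, which gives 259 nM in this assay, a gap that lies beyond the usual scatter, while compound 1 stands furthest from it, also beyond the scatter. No two of these compounds differ in a single place, so no measured step isolates any one change.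

Compound 4 `C[C@@H]1CCCN1c1c(C#N)c2c(N)nc(Nc3ccn(C)n3)cc2n1C` has not yet been measured in this assay. It differs from compound 2 in one place: hydrogen in place of methyl on an aromatic carbon. Among the measured compounds shown here, nothing among the measured compounds shows this change on its own. For compound 4 the step of a 1.6-fold higher number from compound 2 to compound 4 (0.20 log units; within the scatter) is expected to be small, toward a slightly weaker number, and may well stay within the scatter. Compound 4 is therefore estimated at 120 nM, with a range from 45 nM to 320 nM.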

Compound 4, inhibition constant: 13 nM
For compound 4 the middle estimate is 9.2-fold (0.97 log units) above the measured one; the whole stated range lies above it.
By their numbers in this assay, from the lowest: compound 1; then compound 4; then compound 2; then compound 3.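

Going from 1,4-dimethyl-1H-pyrazol-3-yl to 1-methyl-1H-pyrazol-3-yl gives a 5.8-fold lower number from compound 2 to compound 4 (0.76 log units; beyond the scatter) in this assay. Among the compounds shown here, this is the first single-place step, and it shows that the methyl on this aromatic carbon, next to the ring atom that bears a large group, is not required for binding affinity in this pair: the compound with hydrogen there gives the lower number, and a change of one carbon at this position is enough to move the value beyond the scatter. For the compounds shown here, nothing measured so far accounts for the size or direction of this step.

On these data alone, whether fluorine, chlorine, an ethyl or a methoxy on this carbon would sit closer to hydrogen or to methyl remains open. Also open, as far as these compounds go, is whether hydrogen in place of methyl would give a similar step in another compound of the series.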